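Chloro for Trifluoromethyl on the Urea Aryl Ring

The source may hold more compounds than are shown below. What is called first, only, known or untested is meant among the compounds shown, and "the series" means these compounds.

Compound 1 `O=C(Nc1cccc(-n2cc(-c3ccncc3)c(-c3cc(O)cc(Cl)c3)n2)c1)Nc1ccc(Cl)c(C(F)(F)F)c1`: in a functional assay on SR cells (Homo sapiens) for inhibition, read by sulforhodamine B assay, with a stated time of 48 h, tested at 0.01 uM (a higher number here means a weaker effect of the compound at the concentration tested, a lower number a stronger effect), compound 1 gives 105%.
Compound 2 `O=C(Nc1cccc(-n2cc(-c3ccncc3)c(-c3cc(O)cc(Cl)c3)n2)c1)Nc1ccc(Cl)c(Cl)c1`: compound 2 gives 57%.
Compound 3 `COc1cc(Cl)cc(-c2nn(-c3cccc(NC(=O)Nc4ccc(Cl)c(C(F)(F)F)c4)c3)cc2-c2ccncc2)c1`: compound 3 gives 95%.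

Compound 3 stands second highest of the three numbers; its nearest neighbour is shown by the step of a number 10 percentage points lower from compound 1 to compound 3 (within the scatter), while compound 2 lies farther off, beyond the scatter. Compound 4 `COc1cc(Cl)cc(-c2nn(-c3cccc(NC(=O)Nc4ccc(Cl)c(Cl)c4)c3)cc2-c2ccncc2)c1` differs from compound 3 by chloro in place of trifluoromethyl on an aromatic carbon. The same change has been measured once, on the parent lacking the methyl: a number 48 percentage points lower from compound 1 to compound 2 (beyond the scatter). That large step bears directly on the present one, so a drop of similar size is expected, roughly a number 48 percentage points lower from compound 3 to compound 4 (beyond the scatter). Compound 4 is therefore estimated at 47%, with a range from 25% to 75%.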

Compound 4, a percentage reported as activity, at one concentration (the size of the read-out at that concentration, not a potency): 94%
Compound 4: the middle estimate sits 47 percentage points below what was measured, and the stated range ends below it.
By their numbers in this assay, from the lowest: compound 2; then compounds 4, 3 and 1 (each within the scatter of the next, the first and the last beyond it).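

The change from trifluoromethyl to chloro does not carry over between the two cores, for on the core with the methyl on the oxygen it reads a number 1 percentage points lower from compound 3 to compound 4 (within the scatter): the same change on two cores in this assay, a number 48 percentage points lower (beyond the scatter) from compound 1 to compound 2 and a number 1 percentage points lower (within the scatter) from compound 3 to compound 4, 47 percentage points apart, beyond the scatter of two such steps

Likewise, methyl on that oxygen counts with the 3,4-dichlorophenyl group, as a number 37 percentage points higher from compound 2 to compound 4 (beyond the scatter) shows: the same change on two cores in this assay, a number 10 percentage points lower (within the scatter) from compound 1 to compound 3 and a number 37 percentage points higher (beyond the scatter) from compound 2 to compound 4, 47 percentage points apart, beyond the scatter of two such steps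

Only compound 2, which pairs the free hydroxyl with that group, stands apart from the other three, at 57%.

Going by these compounds, whether an ethyl or acetyl on that oxygen, or a bromo or nitrile in place of the chloro, would keep this effect stays open. A single concentration also gives no potency for any of the four compounds.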